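Benzylsulfanyl for ethoxy on a cyclopropylidene-bearing purine core

A few compounds are considered here, and "the series" means these few. Any claim that something is new, unique, unknown or untested is made for them only; others in the source may bear on it.

In an ADME assay on MOLT-3 cells (Homo sapiens) for cytotoxicity, with a stated time of 7 days (on this read-out higher numbers stand for lower toxicity in this test and lower numbers for higher toxicity in this test), compound 1 `CCCCCCSc1nc(N)nc2c1ncn2/C=C1/CC1(CO)CO` gives only a limit, > 20000 nM.
In this assay compound 2 `CCOc1nc(N)nc2c1ncn2/C=C1/CC1(CO)CO` likewise gives only a limit, > 20000 nM.

Compound 2 therefore stands at the limit of this assay, and both values shown sit there (the limit of > 20000 nM in this assay, at which 2 of the 2 values shown sit). Going by the values given here, the one measured step, a step that the two limits leave unreadable from compound 1 to compound 2, cannot be read because both ends are limits, so it gives no size for a change at this carbon.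

Compound 3 `Nc1nc(SCc2ccccc2)c2ncn(/C=C3/CC3(CO)CO)c2n1` differs from compound 2 by benzylsulfanyl in place of ethoxy on an aromatic carbon.

Among the compounds with values here, no measured step bears readably on this change, and the two values shown are limits. Compound 3 is expected to sit at or past the same limit in this assay, with the estimated step that the limit leaves unreadable from compound 2 to compound 3 not readable beyond the scatter. Compound 3 is estimated at 30000 nM, between 12000 nM and 100000 nM.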

Compound 3, half-maximal cytotoxic concentration: > 20000 nM
Compound 3: only a limit was reported; the forecaster's own chance of this, stated with the estimate: 75%; the middle value is on the limit's open side.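

In this assay, going by these compounds alone, compound 3 gives only the limit > 20000 nM and so no step among compound 1, compound 2 and compound 3 can be read. These compounds leave open whether the groups on this aromatic carbon differ at all in cytotoxicity, with every value at one limit: the limit of > 20000 nM in this assay, at which 3 of the 3 values shown sit.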